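The compounds below may be only part of what the source reports. "The series", "measured", "known", "first", "only" and "open" are said of these compounds alone.

Compound 1 `COC(=O)[C@H]1C(/C=C/C(=O)c2ccc([N+](=O)[O-])cc2)=Cc2cc(OC)c(OC)cc2[C@H]1c1cc(OC)c(OC)c(OC)c1`: 20.3 ug/mL
Compound 2 `COC(=O)[C@H]1C(/C=C/C(=O)c2ccc(O)cc2)=Cc2cc(OC)c(OC)cc2[C@H]1c1cc(OC)c(OC)c(OC)c1`: 5.84 ug/mL
Compound 3 `COc1cc2c(cc1OC)[C@@H](c1cc(OC)c(OC)c(OC)c1)[C@H](C(=O)N1CCCC1)C(/C=C/C(=O)c1ccc(C3CCCCC3)cc1)=C2`: 12.8 ug/mL

In a functional assay on DU-145 cells (Homo sapiens) for cytotoxicity, read by sulforhodamine B assay (a lower number here means a stronger inhibitor, a higher number a weaker inhibitor), compound 3 gives 12.8 ug/mL, the second highest of the three numbers. Compound 1 gives 20.3 ug/mL, which lies within the scatter of compound 3. Compound 2 gives 5.84 ug/mL, a lower number that lies beyond the scatter. Compound 4 `COc1cc2c(cc1OC)[C@@H](c1cc(OC)c(OC)c(OC)c1)[C@H](C(=O)N1CCCC1)C(/C=C/C(=O)c1ccc(-c3ccccc3)cc1)=C2` differs from compound 3 by phenyl in place of cyclohexyl on an aromatic carbon. Among the measured compounds shown here, the only measured step, a 3.5-fold lower number from compound 1 to compound 2 (0.54 log units; beyond the scatter), concerns a different place and a different pair of groups, so it does not bear on this change. No swap of a cyclohexyl for a phenyl has been measured here, so the expectation rests on compound 3 alone: the number for compound 4 is expected to stay within the scatter of compound 3, a 1.1-fold lower number from compound 3 to compound 4 (0.03 log units; within the scatter). Compound 4 is therefore estimated at 12 ug/mL, between 4 ug/mL and 35 ug/mL.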

Compound 4, half-maximal inhibitory concentration: 15.5 ug/mL
For compound 4 the middle estimate is 1.3-fold (0.11 log units) below the measured one; measured number inside the range.
By their numbers in this assay, from the lowest: compound 2; then compounds 3, 4 and 1 (each within the scatter of the next).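

In this assay, phenyl in place of cyclohexyl on an aromatic carbon, para to a large group, gives a 1.2-fold higher number from compound 3 to compound 4 (0.08 log units; within the scatter) and so 4-cyclohexylphenyl and 4-phenylphenyl read alike here. Among the compounds shown here, this is the first pair measured at this place, and it shows that a non-aromatic and an aromatic six-membered carbon ring can be exchanged here without a step beyond the scatter. No measurement at hand gives a reason for this. Open, from the compounds shown here alone, is whether an amine or a carboxylic acid at this place would move the number. Also open, going by these compounds, is whether the same exchange would read alike with the methyl ester of compound 1 in place of the amide.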